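A few compounds are considered here, and "the series" means these few. Any claim that something is new, unique, unknown or untested is made for them only; others in the source may bear on it.

In a functional assay on K562 cells (Homo sapiens) for antiproliferative activity, read by MTT assay, with a stated time of 72 h (a higher number here means a weaker inhibitor, a lower number a stronger inhibitor), compound 1 `COc1cc(C(=O)c2sc3ccccc3c2-c2ccccc2)cc(OC)c1OC` gives 2100 nM, compound 2 `COc1cc(C(=O)c2sc3ccccc3c2-c2ccc(SC)cc2)cc(OC)c1OC` gives 1800 nM and compound 3 `COc1cc(C(=O)c2sc3ccccc3c2Nc2ccc(C)cc2)cc(OC)c1OC` gives 1600 nM. Compound 3 thus stands level with the other two, since all three values lie within the scatter of one another. Compound 4 `COc1cc(C(=O)c2sc3cc(C)ccc3c2Nc2ccc(C)cc2)cc(OC)c1OC` keeps everything in compound 3 except for one change, methyl in place of hydrogen on an aromatic carbon of a six-membered aromatic ring of carbon only, part of a fused or bridged system of two rings. For the measured compounds named here, no measured step makes this change at this place. The closest in kind is a 1.2-fold lower number from compound 1 to compound 2 (0.07 log units; within the scatter), also a replacement of hydrogen on an aromatic carbon, and it stays within the scatter. The larger swaps, a 1.3-fold lower number from compound 1 to compound 3 (0.12 log units; within the scatter) and a 1.1-fold lower number from compound 2 to compound 3 (0.05 log units; within the scatter), stay within it too. The data therefore give no reason to expect a shift beyond the scatter in this assay, and the expected change is a 1.2-fold lower number from compound 3 to compound 4 (0.09 log units; within the scatter). For compound 4 the estimate is 1300 nM, with an expected range from 450 nM to 3500 nM.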

Compound 4, half-maximal inhibitory concentration: 1400 nM
Compound 4: middle estimate off by 1.1-fold (0.03 log units), on the low side, within the range that was stated.
By their numbers in this assay, from the lowest: compounds 4, 3, 2 and 1 (each within the scatter of the next).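

In this assay, methyl in place of hydrogen on an aromatic carbon of the six-membered aromatic ring of carbon only, part of a fused or bridged system of two rings, gives a 1.1-fold lower number from compound 3 to compound 4 (0.06 log units; within the scatter). This is the only step among the compounds shown that changes this ring, and it shows that adding one methyl here, on the carbon meta to a fused ring and para to a fused ring, produces no shift beyond the scatter. Nothing available explains this outcome or links it to any property of the methyl group.

From the compounds shown here alone, it remains open whether an amine, a carboxylic acid or a longer chain at this carbon would also stay within the scatter. Going by these compounds, it is equally open whether methyl on the other carbons of this ring would give the same result.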